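The compounds below may be only part of what the source reports. "The series", "measured", "known", "first", "only" and "open" are said of these compounds alone.

Three close relatives share one core and differ only in the ring at the far end of the chain that carries the carbonyl. Compound 1 `COc1cc(/C=C/C(=O)OCCc2ccccc2F)cc(OC)c1O` gives 240 nM in an assay on PMNL cells for inhibition of Polyunsaturated fatty acid 5-lipoxygenase (Homo sapiens), read by HPLC, with stated times of 5 min and 15 min; a higher number here means a weaker inhibitor, a lower number a stronger inhibitor. Compound 2 `COc1cc(/C=C/C(=O)OCCc2cccc(C)c2)cc(OC)c1O` gives 200 nM in this assay, and compound 3 `COc1cc(/C=C/C(=O)OCCc2ccccc2C)cc(OC)c1O` gives 240 nM in this assay. Compound 3 stands level with compound 1, the two together the highest of the three numbers, though the steps of no change at the digits printed from compound 1 to compound 3 (within the scatter) and a 1.2-fold higher number from compound 2 to compound 3 (0.08 log units; within the scatter) both lie within the scatter, as does a 1.2-fold lower number from compound 1 to compound 2 (0.08 log units; within the scatter).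

Compound 4 `COc1ccccc1CCOC(=O)/C=C/c1cc(OC)c(O)c(OC)c1` is not yet measured. It differs from compound 3 by methoxy in place of methyl on an aromatic carbon. Going by the values given here, no measured step brings in a methoxy, so the nearest guide is no change at the digits printed from compound 1 to compound 3 (within the scatter), where one small group replaced another on an aromatic carbon without any shift beyond the scatter; the steps that moved a methyl around the ring were equally flat. The expected step is therefore no change at the digits printed from compound 3 to compound 4 (within the scatter), nothing beyond the scatter. Compound 4 is expected to give 240 nM in this assay, within a range of 120 nM to 480 nM.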

Compound 4, half-maximal inhibitory concentration: 250 nM
Estimate against measurement, compound 4: 1.0-fold (0.02 log units) below; the range from low to high includes it.
By their numbers in this assay, from the lowest: compounds 2, 1, 3 and 4 (each within the scatter of the next).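

Methoxy carries one more heavy atom than methyl, an oxygen counted as a hydrogen-bond acceptor, on the aromatic carbon ortho to a large group, yet in this assay the step is a 1.0-fold higher number from compound 3 to compound 4 (0.02 log units; within the scatter). The other two comparisons agree, with a 1.0-fold higher number from compound 1 to compound 4 (0.02 log units; within the scatter) for methoxy in place of fluoro, and a 1.3-fold higher number from compound 2 to compound 4 (0.10 log units; within the scatter) for 2-methoxyphenyl in place of 3-methylphenyl. Among these compounds, then, this aromatic carbon carries fluoro, methyl or methoxy with no step beyond the scatter, and nothing available here offers a reason for that.

All four numbers lie within the scatter of one another, so the compounds shown reveal no change at this ring that moves the value. Going by these compounds, whether an amine, a carboxylic acid or a longer chain such as ethoxy on this aromatic carbon would shift the number stays open.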